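The source may hold more compounds than are shown below. What is called first, only, known or untested is meant among the compounds shown, and "the series" means these compounds.

Values in an ADME assay on CHO cells (Cricetulus griseus) for cytotoxicity, read by MTT assay, with a stated time of 24 h (a lower number here means that less compound is tolerated, a higher number that more compound is tolerated), so far
- compound 1 `CC1Cn2c(nc([N+](=O)[O-])c2Br)O1` gives 9190 nM
- compound 2 `CCCOc1ccc(-c2c([N+](=O)[O-])nc3n2CC(C)O3)cc1` gives a limit of the assay, not a number (> 125000 nM)
- compound 3 `CC1Cn2c(nc([N+](=O)[O-])c2C#Cc2ccc(CO)cc2)O1` gives 8770 nM

Within the data shown here, only two numbers exist in this set. Compound 3 (8770 nM) and compound 1 (9190 nM) lie within the usual scatter of each other, so neither can be placed ahead of the other.

The next compound to read is compound 4 `CC1Cn2c(nc([N+](=O)[O-])c2C#Cc2ccccc2)O1`, which carries hydrogen in place of hydroxymethyl on an aromatic carbon, para to a large group (hydrogen in place of hydroxymethyl on an aromatic carbon). Among the measured compounds shown here, no step between measured compounds differing in one place is available, so the expectation rests on compound 3 alone (8770 nM). No change beyond the scatter is expected in this assay, in either direction, and the estimated step is small (a 1.1-fold higher number from compound 3 to compound 4 (0.06 log units; within the scatter)). For the measured compounds named here, the range is kept wide since the set offers no direct precedent for this change.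

For compound 4 the estimated value is 10000 nM, with an expected range from 3000 nM to 40000 nM.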

Compound 4, half-maximal cytotoxic concentration: 3540 nM
Estimate against measurement, compound 4: 2.8-fold (0.45 log units) above; the measured number falls inside the stated range.
By their numbers in this assay, from the lowest: compound 4; then compounds 3 and 1 (each within the scatter of the next). At a limit, above all of these: compound 2.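

In this assay, among these compounds, the pair gives the only direct reading of this place, on an aromatic carbon para to a large group: hydrogen in place of hydroxymethyl gives a 2.5-fold lower number from compound 3 to compound 4 (0.39 log units; beyond the scatter), a modest step. A change at this place alone can therefore move the number beyond the scatter, and here the compound with hydrogen tolerates less compound than the one with hydroxymethyl. No measurement shown bears on the reason for this step.

As far as these compounds go, one pair gives one direction at one place, so it remains open whether an amine, a carboxylic acid or a longer chain there would move the number the same way. From the compounds shown here alone, it also remains open whether this change would give a similar step in another compound of the series.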